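This account rests on a few compounds, and the source may have more. Where it says the series, first, only, none or still open, it means among the compounds named here.

Measured compounds:
- compound 1 `OC[C@@]1(c2ccc(F)cc2)NC[C@@H](O)[C@@H]1O` — 6.6%
- compound 2 `Cc1ccc([C@]2(CO)NC[C@@H](O)[C@@H]2O)cc1` — 0%
- compound 3 `COc1ccc([C@]2(CO)NC[C@@H](O)[C@@H]2O)cc1` — 0.2%

Going by the values given here, in an assay on isolated protein for inhibition of alpha-mannosidase (Canavalia ensiformis), tested at 1000 uM (on this read-out lower numbers stand for less inhibition and higher numbers for more inhibition at the one concentration tested (going by the name of the read-out)), compound 2 gives 0%, the smallest of the three numbers as written, but no step separates it from the others beyond the scatter: a number 6.6 percentage points lower from compound 1 to compound 2 (within the scatter), and a number 0.2 percentage points higher from compound 2 to compound 3 (within the scatter). Compound 1 and compound 3 likewise sit together, a number 6.4 percentage points lower from compound 1 to compound 3 (within the scatter). All three numbers lie in the low band of this assay; none of the aryl substituents tested so far moves the read-out.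

Compound 4 `Cc1ccc([C@@]2(CO)NC[C@H](O)[C@H]2O)cc1` is the unmeasured partner of compound 2. The change is the two compounds have the same atoms and bonds and differ only in configuration as drawn: 3 of 3 stereo elements differ (all stereocentres are inverted: mirror images); a stereocentre at a saturated ring carbon is drawn R in compound 2 and S in compound 4; a stereocentre at a saturated ring carbon is drawn R in compound 2 and S in compound 4; a stereocentre at a saturated ring carbon is drawn R in compound 2 and S in compound 4. Among the compounds with values here, none of the measured steps involves a change of configuration: each of them swaps a group on the aromatic ring and leaves the ring carbons untouched, so no measured step bears directly on the step from compound 2 to compound 4. What the series does show is that the measured numbers have stayed within the scatter of each other throughout, and compound 2 itself gives 0%. The three measured compounds give no sign that the stereochemistry tested has any margin over its mirror image.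

The expectation for compound 4 is therefore no step beyond the scatter, a number 2 percentage points higher from compound 2 to compound 4 (within the scatter). Compound 4 is estimated at 2%, with a range from 0% to 12%.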

Compound 4, a percentage reported as inhibition, at one concentration (the size of the read-out at that concentration, not a potency): 0%
The estimate for compound 4 lay 2 percentage points above the measured number; the range from low to high includes it.
By their numbers in this assay, from the lowest: compounds 2, 4, 3 and 1 (each within the scatter of the next).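

In this assay, going by these compounds alone, the mirror-image pair gives the first reading on configuration, with no change at the digits printed from compound 2 to compound 4 (within the scatter). Inverting all three stereocentres opens no margin between the two methyl compounds at the one concentration tested, so configuration joins the aromatic substituent swaps among the changes that leave the read-out unmoved so far. This comparison isolates configuration, with nothing else varying between the two structures: the fact that compounds 2 and 4 differ only in the configuration as drawn.

Compound 2 and compound 4 both lie in the low band of the read-out, so this pair cannot show whether configuration would matter in a compound that gives a clearly higher number, and it says nothing about inverting a single stereocentre while the other two stay fixed. From the compounds shown here alone, it also remains open whether a carboxylic acid or an amine on the aromatic ring, or a longer chain in place of the aromatic group, would lift the number at all, and whether any such compound would then separate from its mirror image.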